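Series notes: chloro to methoxy swap on the methyl core

The source may hold more compounds than are shown below. What is called first, only, known or untested is meant among the compounds shown, and "the series" means these compounds.

Measured so far:
- compound 1 `COc1ccc(-c2cc(O)c3cccnc3n2)cc1`: in a functional assay on 786-0 cells (Homo sapiens) (a lower number here means a stronger inhibitor of growth, a higher number a weaker inhibitor of growth), compound 1 gives 56200 nM
- compound 2 `Oc1cc(-c2ccc(Cl)cc2)nc2ncccc12`: compound 2 gives 33900 nM
- compound 3 `Cc1cnc2nc(-c3ccc(Cl)cc3)cc(O)c2c1`: compound 3 gives 6310 nM

Compound 3 differs from compound 2 in the core by methyl in place of hydrogen on an aromatic carbon. That change gives a 5.4-fold lower number from compound 2 to compound 3 (0.73 log units; beyond the scatter), and compound 3 holds the lowest number of the three.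

Compound 1 differs from compound 2 by methoxy in place of chloro on an aromatic carbon. The step is a 1.7-fold higher number from compound 2 to compound 1 (0.22 log units; within the scatter), so on the unsubstituted core the two values are within scatter of each other and no order between them is claimed.

Compound 4 `COc1ccc(-c2cc(O)c3cc(C)cnc3n2)cc1` is not yet measured. It differs from compound 3 by methoxy in place of chloro on an aromatic carbon, the same change as from compound 2 to compound 1, now made on the methyl-bearing core. Going by the values given here, with only one earlier instance there is no further pattern to lean on.

Among the compounds with values here, compound 4 is expected to show a 1.7-fold higher number from compound 3 to compound 4 (0.23 log units; within the scatter) in this assay, because the one earlier instance gave a 1.7-fold higher number from compound 2 to compound 1 (0.22 log units; within the scatter). The estimate for compound 4 is 10700 nM, with an expected range of 4000 nM to 30000 nM.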

Compound 4, concentration for 50% growth inhibition: 5130 nM
For compound 4 the middle estimate is 2.1-fold (0.32 log units) above the measured one; the measured number falls inside the stated range.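

In this assay, methoxy in place of chloro on the methyl-bearing core gives a 1.2-fold lower number from compound 3 to compound 4 (0.09 log units; within the scatter), so no order is claimed between compound 3 and compound 4, and the swap reads the same on both cores: the same change on two cores in this assay, a 1.7-fold higher number (0.22 log units; within the scatter) from compound 2 to compound 1 and a 1.2-fold lower number (0.09 log units; within the scatter) from compound 3 to compound 4, 2.0-fold (0.31 log units) apart, within the scatter of two such steps

Methyl in place of hydrogen on the methoxy compounds gives an 11-fold lower number from compound 1 to compound 4 (1.04 log units; beyond the scatter), the one change here beyond the scatter on both cores, and its size does not depend measurably on the aromatic substituent: the same change on two cores in this assay, a 5.4-fold lower number (0.73 log units; beyond the scatter) from compound 2 to compound 3 and an 11-fold lower number (1.04 log units; beyond the scatter) from compound 1 to compound 4, 2.0-fold (0.31 log units) apart, within the scatter of two such steps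

This agreement rests on two pairs that form a single square of compounds, so it shows transfer between these two cores only, does not extend to any other core, and gives no explanation of why the methyl step is the larger one.

The compounds shown leave open whether an amine or a carboxylic acid in place of the chloro or methoxy would keep these numbers. They also leave open whether an ethyl group or a longer chain in place of the core methyl would carry the step further.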